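The source may report more compounds than this note shows. Statements on the series, on what has been measured and on what is new or still open speak of the compounds shown alone.

Measured so far:
compound 1 `CCC1C(=O)N(C)c2cnc(-n3ccc4cc(C(=O)NC)ccc43)nc2N1c1ccn(C)n1` gives 6330 nM
compound 2 `CC[C@@H]1C(=O)N(C)c2cnc(Nc3ccc(S(N)(=O)=O)cc3)nc2N1C1CCCC1` gives 317 nM
compound 3 `CCC1C(=O)N(C)c2cnc(Nc3ccc(S(=O)(=O)NCCCO)cc3)nc2N1c1ccn(C)n1` gives 23700 nM

All three were tested in a functional assay on HeLa cells (Homo sapiens) for antiproliferative activity, read by CCK-8 assay, with a stated time of 72 h; a higher number here means a weaker inhibitor of growth, a lower number a stronger inhibitor of growth. Among them compound 3 stands at the highest number: compound 1 sits nearest, compound 2 furthest, and both gaps lie beyond the scatter. Compound 4 `CCC1C(=O)N(C)c2cnc(Nc3ccc(S(=O)(=O)NCCO)cc3)nc2N1c1ccn(C)n1` has not yet been measured. It differs from compound 3 in a single place: hydroxy in place of hydroxymethyl on a saturated chain carbon, two bonds along the chain from a sulfonamide nitrogen. Going by the values given here, no pair of measured compounds differing in just one place exists here, so nothing directly tells how much such a change should matter. The step from compound 3 to compound 4 is expected to be small, with no clear direction beyond the scatter, a 1.3-fold lower number from compound 3 to compound 4 (0.12 log units; within the scatter). Compound 4 is accordingly estimated at 18000 nM, within a range from 6000 nM to 50000 nM.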

Compound 4, concentration for 50% growth inhibition: "not active" (no number reported)
Nothing numeric was reported for compound 4; there is nothing to compare the estimate with.
By their numbers in this assay, from the lowest: compound 2; then compound 1; then compound 3.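

Going by these compounds alone, compound 4 was reported as not active in this assay with no number given, and no step from compound 3 to compound 4 can be read. The compounds shown leave open how much the change from 3-hydroxypropyl to 2-hydroxyethyl shifts growth inhibition. Nothing shown offers an explanation for this result.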